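Chloro step carried from one core to a second

The compounds below may be only part of what the source reports. "The series", "measured", "known", "first", "only" and "open" are said of these compounds alone.

Compound 1 `CCC(=O)Oc1c(OC)c(OC)c(OC(=O)CC)c2ccccc12` and compound 3 `CCC(=O)Oc1c(OC)c(OC)c(OC(=O)CC)c2cc(Cl)ccc12` share a core and differ only by chloro in place of hydrogen on an aromatic carbon. In a physicochemical assay for lipophilicity (a lower number here means a more polar compound, a higher number a more lipophilic compound), compound 1 gives 3.44, and compound 3 gives 4.3; the step between them is a number 0.86 log units higher from compound 1 to compound 3 (beyond the scatter).

Compound 2 `CC(C)(C)C(=O)Oc1c(Oc2ccccc2)c(Oc2ccccc2)c(OC(=O)C(C)(C)C)c2ccccc12` stands on a different core; the difference between the two cores is not broken down here. In this assay compound 2 gives 7.8, the highest of the three numbers, beyond the scatter from compound 3 and from compound 1.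

Compound 4 `CC(C)(C)C(=O)Oc1c(Oc2ccccc2)c(Oc2ccccc2)c(OC(=O)C(C)(C)C)c2cc(Cl)ccc12` has not been measured. It differs from compound 2 by chloro in place of hydrogen on an aromatic carbon, the same change as that from compound 1 to compound 3, and the place is described in the same words in both cases. Among the compounds shown this change occurs twice in all, and only one of the two pairs is measured.

For the measured compounds named here, because a number 0.86 log units higher from compound 1 to compound 3 (beyond the scatter) is the single measured example of this change, the corresponding step in this assay on the core of compound 2 is expected to be of about the same size. Whether the change carries over unchanged from the core of compound 1 to the core of compound 2 rests on that one pair alone, so the range is kept wide. Compound 4 is therefore expected to give 8.6, with an estimated range from 8.1 to 9.2. The expected step is a number 0.80 log units higher from compound 2 to compound 4 (beyond the scatter). Numbers this high may come back from the method as a limit rather than as a value.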

Compound 4, partition coefficient: 8.7
Compound 4: middle estimate off by 0.10 log units, on the low side, and the stated range covers the measured number.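

In this assay, chloro in place of hydrogen on an aromatic carbon gives a number 0.90 log units higher from compound 2 to compound 4 (beyond the scatter), against a number 0.86 log units higher from compound 1 to compound 3 (beyond the scatter) on the other core, so the same change has now been seen at much the same size on two cores. This shows that the step carried over between these two cores in these two pairs, even though compound 2 already stands far higher than compound 1; it does not show that the step would hold on any further core, or that it would hold at another place on the ring. Nothing at hand accounts for the size of either step, or for the closeness of the two.

The compounds shown leave open whether an amine or a carboxylic acid in place of hydrogen on that same aromatic carbon would also give steps of matching size on the two cores. Also open, as far as these compounds go, is whether the chloro step would keep its size on a third core, for instance one carrying a longer chain on its ester groups.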